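This account rests on a few compounds, and the source may have more. Where it says the series, first, only, none or still open, it means among the compounds named here.

Compound 1, `CCN(CC)CCNc1cc(C)c2cc(NC(=O)c3ccc(Cl)c(Cl)c3)ccc2n1`: 1420 nM
Compound 2, `Cc1cc(N2CCCCC2)nc2ccc(NC(=O)c3ccc(Cl)c(Cl)c3)cc12`: 31100 nM
Compound 3, `CNc1cc(C)c2cc(NC(=O)c3ccc(Cl)c(Cl)c3)ccc2n1`: 2520 nM

All three share one core and were tested in a functional assay on MCF7 cells (Homo sapiens) for antiproliferative activity, read by MTT assay, with a stated time of 72 h; a higher number here means a weaker inhibitor, a lower number a stronger inhibitor. Compound 1 gives the lowest number of the three, though the gap to compound 3, a 1.8-fold higher number from compound 1 to compound 3 (0.25 log units; within the scatter), lies within the scatter, so the two cannot be ranked against each other. Compound 2 stands clearly apart: a 22-fold higher number from compound 1 to compound 2 (1.34 log units; beyond the scatter).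

Compound 4, `CCN1CCN(c2cc(C)c3cc(NC(=O)c4ccc(Cl)c(Cl)c4)ccc3n2)CC1`, is not yet measured. It differs from compound 1 in one place: 4-ethylpiperazin-1-yl in place of (2-(diethylamino)ethyl)amino on an aromatic carbon. Within the data shown here, as in the step to compound 2, a chain amine on the aromatic carbon is exchanged for a six-membered ring attached through a ring nitrogen; the ring here carries a second nitrogen with an ethyl group, which compound 2 lacks, and no measured compound tests that feature. The two steps that bear on the question, a 22-fold higher number from compound 1 to compound 2 (1.34 log units; beyond the scatter) and a 12-fold lower number from compound 2 to compound 3 (1.09 log units; beyond the scatter), both show that a ring in this position goes with a much weaker result than a chain or a small amino group. From the compounds shown here alone, a rise in this assay is therefore expected for compound 4, probably smaller than the step to compound 2, since the second nitrogen is untested. Compound 4 is estimated at 8000 nM, with a range from 2500 nM to 25000 nM, which amounts to an expected step of a 5.6-fold higher number from compound 1 to compound 4 (0.75 log units; beyond the scatter).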

Compound 4, half-maximal inhibitory concentration in the MCF7 assay: 1380 nM
For compound 4 the middle estimate is 5.8-fold (0.76 log units) above the measured one; the measured number lies below the stated range.
By their numbers in the MCF7 assay, from the lowest: compounds 4, 1 and 3 (each within the scatter of the next); then compound 2.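

In the MCF7 assay, a ring on this aromatic carbon does not by itself weaken the result, as a 1.0-fold lower number from compound 1 to compound 4 (0.01 log units; within the scatter) and a 1.8-fold lower number from compound 3 to compound 4 (0.26 log units; within the scatter) both show; the hydrogen-bond donor that leaves with the chain can also go without a readable change in this number. The large step, a 23-fold lower number from compound 2 to compound 4 (1.35 log units; beyond the scatter), ties the weak result of compound 2 to piperidin-1-yl, not to every six-membered ring attached through a ring nitrogen at this position. In a physicochemical assay for lipophilicity, at pH 7.4 (on this read-out higher numbers stand for higher lipophilicity and lower numbers for lower lipophilicity), compound 1 gives 1.66 and compound 4 gives 3.67, so two groups that look alike in the antiproliferative read-out differ widely in lipophilicity: the measured distribution coefficient of compound 1, 1.66, and of compound 4, 3.67, a number 2.01 log units higher (beyond the scatter)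

The compounds shown do not separate the second ring nitrogen of compound 4 from the ethyl group it carries, so a piperazine with a methyl group or a plain hydrogen on that nitrogen would be informative. A morpholine ring, with an oxygen in place of that nitrogen, would test whether a nitrogen is needed there at all.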